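The source may hold more compounds than are shown below. What is called first, only, known or untested is meant among the compounds shown, and "the series" means these compounds.

Measured compounds in a functional assay on MCF7 cells (Homo sapiens) for antiproliferative activity, read by MTT assay, with a stated time of 72 h; on this read-out lower numbers stand for stronger inhibition and higher numbers for weaker inhibition:

- compound 1 `Cc1cc(NCCN(C)C)nc2ccc(NC(=O)c3ccc(Cl)c(Cl)c3)cc12` gives 2550 nM
- compound 2 `CCc1ccc(C(=O)Nc2ccc3nc(N4CCN(CC)CC4)cc(C)c3c2)cc1` gives 3060 nM
- compound 3 `CCN1CCN(c2cc(C)c3cc(NC(=O)c4cccc(Br)c4)ccc3n2)CC1` gives 11600 nM

Compound 2 sits second highest of the three numbers in this assay; its value and that of compound 1 lie within the scatter of one another, while compound 3 stands clearly higher, with a 3.8-fold higher number from compound 2 to compound 3 (0.58 log units; beyond the scatter).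

Compound 4 `CCN1CCN(c2cc(C)c3cc(NC(=O)c4ccco4)ccc3n2)CC1` is not yet measured. Against compound 2 it differs at one place only: furan-2-yl in place of 4-ethylphenyl on a carbonyl carbon.

Among the measured compounds shown here, the only measured step touching the group on the carbonyl carbon is a 3.8-fold higher number from compound 2 to compound 3 (0.58 log units; beyond the scatter), where another aryl group in place of 4-ethylphenyl raised the number beyond the scatter. For the measured compounds named here, no measured step covers furan-2-yl itself, so the direction is only partly informed. Taking the one aryl exchange as the nearest guide, a modest rise in this assay is expected for compound 4, in the direction of weaker inhibition, though a step within the scatter cannot be ruled out.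

For compound 4 the estimate in this assay is 7500 nM, with a range of 2800 nM to 25000 nM, corresponding to an expected step of a 2.5-fold higher number from compound 2 to compound 4 (0.39 log units; beyond the scatter).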

Compound 4, half-maximal inhibitory concentration: 41200 nM
The estimate for compound 4 lay 5.5-fold (0.74 log units) below the measured number; measured number outside the range, above it.
By their numbers in this assay, from the lowest: compounds 1 and 2 (each within the scatter of the next); then compound 3; then compound 4.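

In this assay, the group on the carbonyl carbon can shift the number much further than compound 3 alone showed: furan-2-yl in place of 4-ethylphenyl gives a 13-fold higher number from compound 2 to compound 4 (1.13 log units; beyond the scatter), against a 3.8-fold higher number from compound 2 to compound 3 (0.58 log units; beyond the scatter) for 3-bromophenyl. Furan-2-yl also separates from 3-bromophenyl, with a 3.6-fold higher number from compound 3 to compound 4 (0.55 log units; beyond the scatter), so on the shared core both six-membered aromatic rings give lower numbers than the five-membered ring with its oxygen. No measurement is at hand that bears on the reason for this rise.

The compounds shown do not separate the contributions of ring size, the ring oxygen and the ring substituents, since furan-2-yl differs from the other groups in all three. Going by these compounds, how a thiophen-2-yl or an unsubstituted phenyl group would read on this carbonyl carbon remains open.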